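The source may report more compounds than this note shows. Statements on the series, on what has been measured and on what is new or still open speak of the compounds shown alone.

Of the compounds shown here, three have been measured so far in a physicochemical assay on A549 cells for solubility, read by microscopy, with a stated time of 24 h; a higher number here means a weaker inhibitor, a lower number a stronger inhibitor. Compound 1 `COc1ccc(-c2cc(C(=O)N/N=C/c3ccccc3O)n(Cc3ccc(Cl)nc3)n2)cc1` gives 570 nM. Compound 2 `CC(C)(C)c1ccc(Cn2nc(-c3ccccc3)cc2C(=O)N/N=C/c2ccccc2O)cc1` gives 560 nM. Compound 3 `COc1ccc(-c2cc(C(=O)N/N=C/c3ccccc3O)n(Cc3ccccc3)n2)cc1` gives 840 nM, the uppermost of the three numbers, although its gap to each of the other two lies within the usual scatter, so the three cannot be told apart on these figures.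

For the measured compounds named here, only one single-point step is available. It runs a 1.5-fold higher number from compound 1 to compound 3 (0.17 log units; within the scatter), a change on the saturated chain carbon bound to an aromatic nitrogen that left the number essentially unmoved.

Compound 4 `COc1ccc(-c2cc(C(=O)N/N=C/c3ccccc3O)n(Cc3ccc(C(C)(C)C)cc3)n2)cc1` differs from compound 3 in one place: tert-butyl in place of hydrogen on an aromatic carbon. Going by the values given here, compound 2 also carries a tert-butyl group at the corresponding spot, but it differs from compound 3 in a second place as well, so no single step joins them. Compound 2 gives 560 nM and compound 3 gives 840 nM, and these two numbers sit within the scatter of each other.

Among the compounds with values here, the one measured step at this part of the molecule changed nothing beyond the scatter, and the values of compound 2 and compound 3 point the same way. Compound 4 is therefore expected to show a 1.3-fold lower number from compound 3 to compound 4 (0.11 log units; within the scatter), and its estimated result is 650 nM, with a likely range from 350 nM to 1200 nM.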

Compound 4, half-maximal inhibitory concentration: 550 nM
The estimate for compound 4 lay 1.2-fold (0.07 log units) above the measured number, and the stated range covers the measured number.
By their numbers in this assay, from the lowest: compounds 4, 2, 1 and 3 (each within the scatter of the next).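

In this assay, placing tert-butyl on the aromatic carbon of the benzyl ring gives a 1.5-fold lower number from compound 3 to compound 4 (0.18 log units; within the scatter) and stays within the scatter, so this position holds a group of four carbons with no readable effect on the number. The step at the other aromatic ring, methoxy in place of hydrogen, gives a 1.0-fold lower number from compound 2 to compound 4 (0.01 log units; within the scatter) and also lies within the scatter, which shows that with tert-butyl present, methoxy at that place cannot be told apart from hydrogen. Replacing 6-chloropyridin-3-yl with 4-(tert-butyl)phenyl on the saturated chain carbon gives a 1.0-fold lower number from compound 1 to compound 4 (0.02 log units; within the scatter) and is within the scatter too, so phenyl, 6-chloropyridin-3-yl and 4-(tert-butyl)phenyl at this carbon have so far given numbers that cannot be separated.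

Going by these compounds, whether an amine or a carboxylic acid on the same aromatic carbon, or a longer chain in place of tert-butyl, would move the number beyond the scatter remains open. No measurement at hand offers an explanation for why these changes leave the number so little moved.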